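From hydroxy to methoxy on compound 1

The source may hold more compounds than are shown below. What is called first, only, known or untested is meant among the compounds shown, and "the series" means these compounds.

In an ADME assay on J744 cells (Mus musculus) for cytotoxicity, read by MTT assay, with a stated time of 48 h (on this read-out higher numbers stand for weaker inhibition and lower numbers for stronger inhibition), compound 1 (`COc1cc(/C=N/NC(=O)c2no[n+]([O-])c2C)ccc1O`) gives > 400000 nM as its result, and this is a limit of the assay, not a number. It is the only such limit among the measurements so far (the limit of > 400000 nM in this assay, at which 1 of the 3 values shown sits). Two further compounds have numerical results: compound 2 (`O=C(N/N=C/c1ccc2no[n+]([O-])c2c1)c1cccnc1`) gives 31000 nM in this assay and compound 3 (`O=C(N/N=C/c1c(-c2ccccc2)no[n+]1[O-])c1cnn(-c2ccccc2)c1`) gives 42000 nM in the same test. Neither of them differs from compound 1 in only one place, so the measured compounds offer no direct guide to the next step.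

Compound 4 (`COc1ccc(/C=N/NC(=O)c2no[n+]([O-])c2C)cc1OC`) differs from compound 1 by one change (methyl in place of hydrogen on an oxygen on an aromatic ring), methyl in place of hydrogen on an oxygen on an aromatic ring, which turns hydroxy to methoxy. Among the compounds with values here, with no measured example of this change, no direction can be favoured, and no shift beyond the usual scatter is expected. This expectation rests on compound 1 alone, whose result of > 400000 nM is a limit. The estimated step in this assay is a number no higher from compound 1 to compound 4 (the limit leaves the size open) and the outcome is expected to be a limit again. For compound 4 the estimated value is 400000 nM with an expected range from 120000 nM to 800000 nM in this test.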

Compound 4, half-maximal inhibitory concentration: > 400000 nM
Compound 4: a limit, no number; the forecaster's own chance of this, stated with the estimate: 50%; the middle value lies on the limit itself.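

Compound 1 and compound 4 both give a limit of the assay in this assay rather than a number, so no step can be read between them: the limit of > 400000 nM in this assay, at which 2 of the 4 values shown sit.

The compounds shown leave open whether methyl in place of hydrogen on an oxygen on an aromatic ring changes the result in this assay at all.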